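This account rests on a few compounds, and the source may have more. Where it says the series, first, only, none or still open, it means among the compounds named here.

In a physicochemical assay for solubility, in phosphate buffer, measured as thermodynamic solubility, at pH 7.4 (a lower number here means a less soluble compound, a higher number a more soluble compound), compound 1 `CS(=O)(=O)NC(=O)CCc1cn(-c2ccc(Br)cc2)nc1C1CCN(C=O)CC1` gives 200000 nM and compound 3 `CC(CC(=O)NS(C)(=O)=O)c1cn(-c2ccc(Cl)cc2)nc1-c1ccncc1` gives 170000 nM. Compound 2 `CS(=O)(=O)NCCCc1cn(-c2ccc(Br)cc2)nc1-c1ccc(Cl)cc1` reports < 5000 nM, which is a limit and not a number. Its place on the scale is the limit of < 5000 nM in this assay, at which 1 of the 3 values shown sits. Compound 4 `O=c1[nH]nc(CCc2cn(-c3ccc(Br)cc3)nc2-c2ccc(Cl)cc2)o1` has not yet been measured in this assay. It departs from compound 2 in one place: a group of 6 heavy atoms (2 carbon, 2 nitrogen, 2 oxygen; one five-membered aromatic ring with 3 hetero atoms) in place of a group of 6 heavy atoms (2 carbon, 1 nitrogen, 2 oxygen, 1 sulfur; no ring), on a saturated chain carbon, two bonds along the chain from an aromatic carbon. A five-membered aromatic ring with 3 hetero atoms thus stands in place of the (methanesulfonamido)methyl group, on a saturated chain carbon, two bonds along the chain from an aromatic carbon. Among the compounds with values here, no measured pair shows this change, so only a modest upward move is expected, an estimated step of an at least 3.0-fold higher number from compound 2 to compound 4 (0.47 log units; beyond the scatter). The expected value for compound 4 is 15000 nM, within an estimated range of 3000 nM to 90000 nM.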

Compound 4, solubility: < 5000 nM
Compound 4 ended at the assay's limit; the forecaster's own chance of this, stated with the estimate: 30%; middle value at least 3.0-fold (0.47 log units) from the limit.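

Within the data shown here, compound 2 and compound 4 both end at a limit and not at a number, so no step between them can be read: the limit of < 5000 nM in this assay, at which 2 of the 4 values shown sit. The compounds shown leave open how far apart compound 2 and compound 4 really lie, and in which direction.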